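A few compounds are considered here, and "the series" means these few. Any claim that something is new, unique, unknown or untested is made for them only; others in the source may bear on it.

Measured compounds:
- compound 1, `O/N=C(/Nc1ccc(F)c(F)c1)c1ccc2occc2c1`: 22700 nM
- compound 2, `O/N=C(/Nc1ccc(F)c(C(F)(F)F)c1)c1ccc2occc2c1`: 1200 nM
- compound 3, `O/N=C(/NCc1ccccc1)c1ccc2occc2c1`: > 30000 nM

Compound 3 stands apart from the other two. In an assay on isolated protein for inhibition of Indoleamine 2,3-dioxygenase 1 (Homo sapiens), read by spectrophotometry (a higher number here means a weaker inhibitor, a lower number a stronger inhibitor), compound 3 gives > 30000 nM, which is a limit of the assay and not a number; it sits at the limit of > 30000 nM in this assay, at which 1 of the 3 values shown sits. Compound 1 gives 22700 nM and compound 2 gives 1200 nM; the only step among these, a 19-fold lower number from compound 1 to compound 2 (1.28 log units; beyond the scatter), runs on the aryl amine side of the shared core and says nothing about the benzyl amine of compound 3.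

Compound 4, `O/N=C(/NCc1ccco1)c1ccc2occc2c1`, differs from compound 3 by furan-2-yl in place of phenyl on a saturated chain carbon bound to an amine nitrogen. Among the measured compounds shown here, no measured step touches this part of the molecule, so the size of the move in this assay cannot be read from the data; the only anchor is that compound 3 already sits at the limit. The step of a number no higher from compound 3 to compound 4 (the limit leaves the size open) is therefore the expected size, with no change beyond the scatter expected. For compound 4 the estimate is 30000 nM, ranging from 8000 nM to 100000 nM, with a real chance that only a limit is reported again.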

Compound 4, half-maximal inhibitory concentration: > 30000 nM
Compound 4: no number, only a limit; the forecaster's own chance of this, stated with the estimate: 65%; the middle value lies on the limit itself.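

In this assay compound 4, like compound 3, gives only a limit and not a number, so no step between the two can be read: the limit of > 30000 nM in this assay, at which 2 of the 4 values shown sit.

The compounds shown leave open whether furan-2-yl in place of phenyl changes anything in this assay, and how far either compound lies from that limit.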